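A few compounds are considered here, and "the series" means these few. Any claim that something is new, unique, unknown or untested is made for them only; others in the source may bear on it.

Measured so far:
Compound 1, `COc1ccc(-c2ncnn2-c2cc(OC)c(OC)c(OC)c2)cc1`: 360 nM
Compound 2, `CCOc1ccc(-c2ncnn2-c2cc(OC)c(OC)c(OC)c2)cc1Cl`: 17 nM
Compound 3, `COc1cc(-c2ncnn2-c2ccc(F)cc2)cc(OC)c1OC`: > 10000 nM

In a functional assay on MCF7 cells (Homo sapiens) for antiproliferative activity, read by MTT assay, with a stated time of 72 h (a lower number here means a stronger inhibitor, a higher number a weaker inhibitor), compound 1 gives 360 nM, the higher of the two numbers. Compound 2 gives 17 nM, a gap beyond the scatter. Compound 3 gives > 10000 nM, which is a limit of the assay and not a number; that is the limit of > 10000 nM in this assay, at which 1 of the 3 values shown sits.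

Compound 4, `COc1cc(-n2ncnc2-c2ccc(SC)cc2)cc(OC)c1OC`, is not yet measured. It differs from compound 1 in one place:
methylsulfanyl in place of methoxy on an aromatic carbon
Among the measured compounds shown here, no measured pair here shows the effect of such a swap. The expected step for compound 4 is therefore a 1.2-fold lower number from compound 1 to compound 4 (0.08 log units; within the scatter), small and not clearly beyond the scatter in either direction. Compound 4 is estimated to give 300 nM, with a likely range from 80 nM to 1500 nM.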

Compound 4, half-maximal inhibitory concentration: 390 nM
The estimate for compound 4 lay 1.3-fold (0.11 log units) below the measured number, within the range that was stated.
By their numbers in this assay, from the lowest: compound 2; then compounds 1 and 4 (each within the scatter of the next). At a limit, above all of these: compound 3.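

In this assay, methylsulfanyl in place of methoxy on the aromatic carbon gives a 1.1-fold higher number from compound 1 to compound 4 (0.03 log units; within the scatter). Among the compounds shown here, this is the first single change measured at this position, and in this assay the sulfur-containing group cannot be told apart from the oxygen-containing one. Nothing measured here gives a reason for this match. The compounds shown leave open how an amine, a hydroxyl group or a longer chain such as ethylsulfanyl would fare at this position. They also leave open whether the match between methoxy and methylsulfanyl would hold in other cell lines.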